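Benzothiazole amides of the shared core: cytotoxicity notes

The compounds below may be only part of what the source reports. "The series", "measured", "known", "first", "only" and "open" are said of these compounds alone.

Compound 2 `COc1ccc2nc(NC(=O)c3cc(-c4ccc(F)cc4)n4nc(-c5ccccc5)cc4n3)sc2c1` in a functional assay on DU-145 cells (Homo sapiens) for cytotoxicity, read by MTT assay, with a stated time of 48 h (a lower number here means a stronger inhibitor, a higher number a weaker inhibitor), gives 15400 nM, the lowest of the two numbers measured, though its nearest neighbour compound 1 `O=C(Nc1nc2ccc(F)cc2s1)c1cc(-c2ccc(F)cc2)n2nc(-c3ccccc3)cc2n1` gives 22900 nM, and the step of a 1.5-fold lower number from compound 1 to compound 2 (0.17 log units; within the scatter) stays within the scatter. Compound 3 `Cc1cc2nc(NC(=O)c3cc(-c4ccc(F)cc4)n4nc(-c5ccccc5)cc4n3)sc2cc1C` differs from compound 2 by 5,6-dimethyl-1,3-benzothiazol-2-yl in place of 6-methoxy-1,3-benzothiazol-2-yl on an amide-type nitrogen. For the measured compounds named here, the only step that bears on this place is the one from compound 1 to compound 2, and it was small. Compound 3 is therefore expected to show no change beyond the scatter, a step of a 1.0-fold higher number from compound 2 to compound 3 (0.02 log units; within the scatter). The estimate for compound 3 in this assay is 16000 nM, within the range 5000 nM to 50000 nM.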

Compound 3, half-maximal inhibitory concentration: 12900 nM
For compound 3 the middle estimate is 1.2-fold (0.09 log units) above the measured one, within the range that was stated.
By their numbers in this assay, from the lowest: compounds 3, 2 and 1 (each within the scatter of the next).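

In this assay, 5,6-dimethyl-1,3-benzothiazol-2-yl in place of 6-methoxy-1,3-benzothiazol-2-yl gives a 1.2-fold lower number from compound 2 to compound 3 (0.08 log units; within the scatter), and in place of 6-fluoro-1,3-benzothiazol-2-yl it gives a 1.8-fold lower number from compound 1 to compound 3 (0.25 log units; within the scatter), so neither step leaves the scatter. At this place on the amide-type nitrogen, the methoxy oxygen can therefore give way to carbon without a change that can be read. No measurement available here explains these steps.

As far as these compounds go, whether an amine or a carboxylic acid on the benzothiazole would move the number beyond the scatter stays open. So does the effect of a longer alkyl chain there.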